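Swapping acetyl for trifluoromethoxy in a cell toxicity test

A few compounds are considered here, and "the series" means these few. Any claim that something is new, unique, unknown or untested is made for them only; others in the source may bear on it.

Compound 1 (`CC(=O)c1ccc(NC(=O)Nc2cc(C)nc3ccccc23)cc1`): 22000 nM
Compound 2 (`Cc1cc(NC(=O)Nc2cc(Cl)cc(Cl)c2)c2ccccc2n1`): > 25000 nM (a limit)

For the measured compounds named here, in an ADME assay on BJ cells (Homo sapiens) for cytotoxicity, with a stated time of 72 h (on this read-out lower numbers stand for an effect already at smaller amounts and higher numbers for an effect only at larger amounts of compound), compound 1 gives 22000 nM as the only true number so far. Compound 2 gives > 25000 nM which is a limit of the assay and not a number. Compound 3 (`Cc1cc(NC(=O)Nc2ccc(OC(F)(F)F)cc2)c2ccccc2n1`) has not been measured yet. It differs from compound 1 in one place, with trifluoromethoxy in place of acetyl on an aromatic carbon, para to a large group (trifluoromethoxy in place of acetyl on an aromatic carbon). Going by the values given here, no measured pair shows what a single change does here, so any expectation is tentative. Given compound 1 at 22000 nM, no step beyond the usual scatter is expected. Given (the limit of > 25000 nM in this assay, at which 1 of the 2 values shown sits), only a limit may be reported for compound 3. The estimated step of a 1.1-fold lower number from compound 1 to compound 3 (0.04 log units; within the scatter) stays within that scatter. The estimated value for compound 3 is 20000 nM (expected range 9000 nM to 40000 nM).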

Compound 3, half-maximal effective concentration: 25000 nM
The estimate for compound 3 lay 1.3-fold (0.10 log units) below the measured number; measured number inside the range.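

For the compounds shown here, this is the first step measured at this place, on an aromatic carbon of a six-membered aromatic ring of carbon only, para to a large group. In this assay, putting trifluoromethoxy in place of acetyl gives a 1.1-fold higher number from compound 1 to compound 3 (0.06 log units; within the scatter), so the two compounds cannot be told apart here, even though the entering group has more heavy atoms and brings in fluorine. Little room for a measured rise is visible, as the read-out also reaches a limit, which is not a number: the limit of > 25000 nM in this assay, at which 1 of the 3 values shown sits.

The compounds shown leave open whether a different kind of group at this place, such as an amine or a carboxylic acid, would move the number beyond the scatter. They also leave open whether a change elsewhere on the shared core would do so.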